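This account rests on a few compounds, and the source may have more. Where it says the series, first, only, none or still open, it means among the compounds named here.

Compound 1 `COc1ccc(S(=O)(=O)c2cnc3cc(F)ccc3c2N2CCC(C)CC2)cc1OC`: 83%
Compound 2 `COc1ccc(S(=O)(=O)c2cnc3ccc(Cl)cc3c2N2CCC(C)CC2)cc1Cl`: 46%

In an assay on isolated protein for displacement of a labelled ligand from metabotropic glutamate receptor 5 (Homo sapiens), with a stated time of 60 min, tested at 1 uM (on this read-out lower numbers stand for less inhibition and higher numbers for more inhibition at the one concentration tested (going by the name of the read-out)), compound 1 gives 83%, the higher of the two measured numbers, and compound 2 lies well below it, a gap beyond the usual scatter. Compound 3 `COc1cccc(S(=O)(=O)c2cnc3cc(F)ccc3c2N2CCC(C)CC2)c1` is compound 1 with one change: hydrogen in place of methoxy on an aromatic carbon. For the measured compounds named here, no measured pair shows this same change, so its size is not known from the numbers at hand. A moderate drop is expected from compound 1 to compound 3, a number 18 percentage points lower from compound 1 to compound 3 (beyond the scatter), since only compound 1 with 83% anchors the guess. Compound 3 is therefore estimated at 65%, within 40% to 85%.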

Compound 3, a percentage reported as inhibition, at one concentration (the size of the read-out at that concentration, not a potency): 90%
Compound 3: middle estimate off by 25 percentage points, on the low side; measured number above the stated range.
By their numbers in this assay, from the lowest: compound 2; then compounds 1 and 3 (each within the scatter of the next).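

In this assay, the step of a number 7 percentage points higher from compound 1 to compound 3 (within the scatter) lies within the scatter. The methoxy group on this aromatic carbon, para to a large group, can therefore be replaced by hydrogen without a measurable loss of inhibition at the one concentration tested, and 3-methoxyphenyl does as well here as 3,4-dimethoxyphenyl. Nothing available explains this result. Still open, as far as these compounds go, is whether a larger group at this place, such as ethoxy or an amine, would keep the inhibition, and whether the remaining methoxy group matters.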